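From 4-pentylphenyl to butyl on a triple-bonded carbon

The compounds below may be only part of what the source reports. "The series", "measured", "known", "first", "only" and "open" are said of these compounds alone.

Measured in a functional assay on MOLT-4 cells (Homo sapiens) for antiproliferative activity, read by MTT assay, with a stated time of 3 days; on this read-out lower numbers stand for stronger inhibition and higher numbers for weaker inhibition:
- compound 1 `Cc1ccc(C#Cc2cn(C/C=C\CN3C(=O)c4ccccc4C3=O)c(=O)[nH]c2=O)cc1` gives 266000 nM
- compound 2 `CCCCCc1ccc(C#Cc2cn(C/C=C\CN3C(=O)c4ccccc4C3=O)c(=O)[nH]c2=O)cc1` gives 30000 nM
- compound 3 `CCCCCc1ccc(C#Cc2cn(C/C=C/CN3C(=O)c4ccccc4C3=O)c(=O)[nH]c2=O)cc1` gives 17000 nM

Compound 3 shares the low end of these numbers with compound 2, the two lying within the scatter of each other, while compound 1 lies clearly higher. Compound 4 `CCCCC#Cc1cn(C/C=C/CN2C(=O)c3ccccc3C2=O)c(=O)[nH]c1=O` has not yet been measured. It carries butyl in place of 4-pentylphenyl on a triple-bonded carbon, a change counted as butyl in place of 4-pentylphenyl on a triple-bonded carbon. Among the compounds with values here, only one measured step touches this side group: an 8.9-fold lower number from compound 1 to compound 2 (0.95 log units; beyond the scatter), with butyl added to the chain, suggests that losing carbon here raises the number. The double-bond step, a 1.8-fold lower number from compound 2 to compound 3 (0.25 log units; within the scatter), lies within the scatter, and compound 4 keeps the drawn configuration of compound 3. The estimated change is a 7.1-fold higher number from compound 3 to compound 4 (0.85 log units; beyond the scatter), an expected move toward weaker inhibition, beyond the scatter. Compound 4 is therefore expected at about 120000 nM, with an estimated range from 40000 nM to 400000 nM.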

Compound 4, half-maximal inhibitory concentration: 171000 nM
For compound 4 the middle estimate is 1.4-fold (0.15 log units) below the measured one; the measured number falls inside the stated range.
By their numbers in this assay, from the lowest: compounds 3 and 2 (each within the scatter of the next); then compounds 4 and 1 (each within the scatter of the next).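

In this assay the step of a 10-fold higher number from compound 3 to compound 4 (1.00 log units; beyond the scatter) replaces 4-pentylphenyl with butyl on a triple-bonded carbon. The earlier side-group step changed only the chain on the aromatic ring, whereas this one removes the ring and leaves an open chain, so butyl does not stand in for 4-pentylphenyl at this position in this pair. Nothing given here explains why the number rises so much on this change:.

From the compounds shown here alone, what stays open is how much of the step belongs to the loss of the ring and how much to the shorter chain. A plain phenyl group or a longer open chain such as octyl on the same triple-bonded carbon, with the rest of compound 3 kept, would help separate these two parts.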